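Swapping a long chain for a thiazole on an adenosine hydrazone

The source may report more compounds than this note shows. Statements on the series, on what has been measured and on what is new or still open speak of the compounds shown alone.

Measured so far:
compound 1, `Nc1nc(N/N=C/c2ccc(OCc3ccc(F)cc3)cc2)nc2c1ncn2[C@@H]1O[C@H](CO)[C@@H](O)[C@H]1O`, gives 70 nM
compound 2, `CCCCC/C=C/C=C/C=N/Nc1nc(N)c2ncn([C@@H]3O[C@H](CO)[C@@H](O)[C@H]3O)c2n1`, gives 2 nM

Both compounds were tested in an assay on CHO-K1 cells for displacement of a labelled ligand from adenosine receptor A1 (Homo sapiens), read by scintillation counting, with a stated time of 60 min; a lower number here means a stronger inhibitor, a higher number a weaker inhibitor. Of the two numbers, compound 2 has the lower one, with 2 nM, and compound 1 sits at 70 nM, a gap that is well beyond the usual scatter of the method. Compound 2 is therefore the stronger inhibitor of this pair.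

Compound 3, `Nc1nc(N/N=C/c2cncs2)nc2c1ncn2[C@@H]1O[C@H](CO)[C@@H](O)[C@H]1O`, is not yet measured. It differs from compound 2 by a group of 5 heavy atoms (3 carbon, 1 nitrogen, 1 sulfur; one five-membered aromatic ring with 2 hetero atoms) in place of a group of 9 heavy atoms (9 carbon; no ring), on a carbon with a double bond to nitrogen. In plain terms, a chain with no ring gives way to a small aromatic ring bearing two hetero atoms, attached at the same carbon of the hydrazone.

Among the measured compounds shown here, no measured pair shows exactly this kind of exchange, so any expectation rests on the two numbers at hand, where the ring-bearing compound 1 is the weaker of the two. Compound 3 is expected to land between the two measured values, with a step of a 20-fold higher number from compound 2 to compound 3 (1.30 log units; beyond the scatter) from compound 2. The estimate for compound 3 in this assay is 40 nM, with a range from 8 nM to 200 nM.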

Compound 3, inhibition constant: 22 nM
For compound 3 the middle estimate is 1.8-fold (0.26 log units) above the measured one; measured number inside the range.
By their numbers in this assay, from the lowest: compound 2; then compound 3; then compound 1.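

In this assay the exchange of the open chain of 9 carbons for 1,3-thiazol-5-yl gives an 11-fold higher number from compound 2 to compound 3 (1.04 log units; beyond the scatter) and so lies beyond the scatter, which shows that the group on this carbon with a double bond to nitrogen has a large bearing on the number. Among the compounds shown here, in this single exchange the chain gives the stronger inhibitor, yet the printed values also show that a ring at this carbon need not give a number as high as the one for compound 1: compound 3 gives 22 nM while compound 1 gives 70 nM in the same test. Nothing available here explains why the step has this size.

The compounds shown leave open whether the step comes from losing the chain or from gaining the ring, since a single exchange changes both at once. What a shorter saturated chain, such as butyl, or a thiophene ring, which would test the nitrogen of the thiazole, would give at this same carbon also remains to be seen.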